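The source may report more compounds than this note shows. Statements on the series, on what has been measured and on what is new or still open speak of the compounds shown alone.

Compound 1 `C=CC(=O)N1C(=O)CC(c2ccc(OC)cc2)Sc2ccccc21` is the reference point of this small set. In a functional assay on Raji cells (Homo sapiens) for cytotoxicity, read by CCK-8 assay, with a stated time of 24 h (on this read-out lower numbers stand for stronger inhibition and higher numbers for weaker inhibition), compound 1 gives 43300 nM, the lowest of the three numbers recorded so far. Compound 2 `C=CC(=O)N1C(=O)CC(c2ccc(C(=O)OC)cc2)Sc2ccccc21` gives 89600 nM in this assay, and compound 3 `C=CC(=O)N1C(=O)CC(c2ccc(-c3ccccc3)cc2)Sc2ccccc21` gives 56300 nM. The step of a 2.1-fold higher number from compound 1 to compound 2 (0.32 log units; beyond the scatter) is the only one beyond the scatter; the step of a 1.3-fold higher number from compound 1 to compound 3 (0.11 log units; within the scatter) and the step of a 1.6-fold lower number from compound 2 to compound 3 (0.20 log units; within the scatter) both fall within it.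

Compound 4 `C=CC(=O)N1C(=O)CC(c2cccs2)Sc2ccccc21` has not yet been measured. It differs from compound 1 by thiophen-2-yl in place of 4-methoxyphenyl on a saturated ring carbon. All three measured steps alter the same aromatic ring that this change removes, but each of them only exchanges the group on that ring, whereas here the whole ring is replaced. The measured steps therefore bear only loosely on the change: they show that exchanging groups on that ring moves the number by no more than a modest amount in either direction, with the largest shift being a 2.1-fold higher number from compound 1 to compound 2 (0.32 log units; beyond the scatter). On that basis a step of no more than modest size is expected for compound 4, with no firm direction and possibly none beyond the scatter. For compound 4 the expected step is a 1.3-fold higher number from compound 1 to compound 4 (0.10 log units; within the scatter), and the expected value in this assay is 55000 nM, in a range from 22000 nM to 140000 nM.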

Compound 4, half-maximal inhibitory concentration: 659000 nM
Beside the measured number, compound 4's estimate is 12-fold (1.08 log units) below it; the whole stated range lies below it.
By their numbers in this assay, from the lowest: compounds 1, 3 and 2 (each within the scatter of the next, the first and the last beyond it); then compound 4.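

In this assay, replacing the whole aromatic ring on the saturated ring carbon next to the ring sulfur gives a 15-fold higher number from compound 1 to compound 4 (1.18 log units; beyond the scatter), a large step, whereas the largest step among the earlier exchanges on that ring was a 2.1-fold higher number from compound 1 to compound 2 (0.32 log units; beyond the scatter). For the compounds shown here, compounds 1, 2 and 3 showed only that the group carried on the phenyl ring could be exchanged with limited movement in the number; compound 4 shows that this position is far from indifferent to the ring itself, and that exchanging 4-methoxyphenyl for thiophen-2-yl comes with a much weaker number. This single change swaps a six-membered carbon ring for a five-membered ring with a sulfur atom and also removes the methoxy group, and no evidence is available on what lies behind the step.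

The compounds shown leave open whether the ring change or the loss of the methoxy group carries the step, a question that an unsubstituted phenyl group or a methoxy-bearing thiophene at this carbon would address. They also leave open whether another five-membered ring, such as thiophen-3-yl or furan-2-yl, would behave like thiophen-2-yl.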